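The source may report more compounds than this note shows. Statements on the series, on what has been measured and on what is new or still open speak of the compounds shown alone.

Of the compounds shown here, three have been measured in a functional assay on HepG2 cells (Homo sapiens) for antiproliferative activity, read by MTT assay, with a stated time of 48 h; a higher number here means a weaker inhibitor, a lower number a stronger inhibitor. Compound 1 `N#CC1=C(N)Oc2c(c3nc4ccccc4nc3c3ccccc23)C12C(=O)N(Cc1cnnn1-c1ccccc1Br)c1ccccc12` and compound 2 `N#CC1=C(N)Oc2c(c3nc4ccccc4nc3c3ccccc23)C12C(=O)N(Cc1cnnn1-c1cccc(Br)c1)c1ccccc12` share one core; compound 3 `N#CC1=C(N)Oc2c(N)cc3nc4ccccc4nc3c2C12C(=O)N(Cc1cnnn1-c1cccc(Br)c1)c1ccccc12` carries a different core, and the difference between the two cores is not broken down here. In this assay compound 1 reaches only the limit > 50000 nM. Compound 2 likewise reaches only the limit > 50000 nM. Compound 3 also reaches only the limit > 50000 nM. The change 2-bromophenyl in place of 3-bromophenyl on an aromatic nitrogen therefore gives a step that the two limits leave unreadable from compound 2 to compound 1 that cannot be read, because of the limit of > 50000 nM in this assay, at which 3 of the 3 values shown sit. Compound 4 `N#CC1=C(N)Oc2c(N)cc3nc4ccccc4nc3c2C12C(=O)N(Cc1cnnn1-c1ccccc1Br)c1ccccc12` carries the same change 2-bromophenyl in place of 3-bromophenyl on an aromatic nitrogen on the core of compound 3. Among the compounds with values here, since every value so far sits at the limit (the limit of > 50000 nM in this assay, at which 3 of the 3 values shown sit), compound 4 is expected to behave alike, with an estimated step that the limit leaves unreadable from compound 3 to compound 4. Compound 4 is therefore estimated at 80000 nM, between 30000 nM and 250000 nM.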

Compound 4, half-maximal inhibitory concentration: 38000 nM
Compound 4: the middle estimate sits 2.1-fold (0.32 log units) above what was measured; low and high end bracket the measured number.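

In this assay, 2-bromophenyl in place of 3-bromophenyl on the core of compound 3 gives an at least 1.3-fold lower number from compound 3 to compound 4 (0.11 log units; that floor lies within the scatter). The same change on the core of compound 1 cannot be read, because both values there are limits of the assay, not numbers: the limit of > 50000 nM in this assay, at which 3 of the 4 values shown sit. Compound 4 thus shows that a readable number can occur with this change on one core, but the series does not show that the step carries from one core to the other, or how large it truly is.

The compounds shown leave open how a plain phenyl, a chlorophenyl or a benzyl group on that aromatic nitrogen would read. They also leave open whether the bromine matters at all.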